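This account rests on a few compounds, and the source may have more. Where it says the series, first, only, none or still open, it means among the compounds named here.

Measured so far in an ADME assay on MIA PaCa-2 cells (Homo sapiens) for cytotoxicity, read by MTT assay, with a stated time of 72 h; a lower number here means a stronger inhibitor, a higher number a weaker inhibitor:
- compound 1 `C=CCOc1cc(C2=C(c3cc(OC)c(OC)c(OC)c3)C(=O)C(O)C2)ccc1OC`: > 100 ug/mL
- compound 2 `COc1ccc(C2=C(c3cc(OC)c(OC)c(OC)c3)CC(O[SiH2]C(C)(C)C)C2=O)cc1[N+](=O)[O-]`: > 100 ug/mL

Compound 1 stands at > 100 ug/mL, which is a limit of the assay and not a number. Compound 2 reads > 100 ug/mL, also a limit. Going by the values given here, the whole record so far is the limit of > 100 ug/mL in this assay, at which 2 of the 2 values shown sit, and no numeric step exists between measured compounds.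

Next is compound 3 `COc1ccc(C2=C(c3cc(OC)c(OC)c(OC)c3)C(=O)C(O)C2)cc1OC(C)C`, with the change isopropyl in place of allyl on an oxygen on an aromatic ring. No step beyond the scatter is expected in this assay, in either direction. That expectation rests on compound 1 at > 100 ug/mL, a limit. The expected step is a number no higher from compound 1 to compound 3 (the limit leaves the size open). For compound 3 the estimated value is 100 ug/mL, with an expected range from 25 ug/mL to 200 ug/mL.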

Compound 3, half-maximal inhibitory concentration: > 100 ug/mL
Compound 3 ended at the assay's limit (the forecaster's own chance of this, stated with the estimate: 65%); the middle value sits exactly at the limit.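

No step can be read from compound 1 to compound 3 in this assay, as both values are limits and not numbers: the limit of > 100 ug/mL in this assay, at which 3 of the 3 values shown sit.

The compounds shown leave open whether isopropyl in place of allyl, or any other change on the shared core, moves the read-out at all.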